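A few compounds are considered here, and "the series" means these few. Any claim that something is new, unique, unknown or untested is made for them only; others in the source may bear on it.

For the measured compounds named here, in a functional assay on KB 3-1 cells (Homo sapiens) for cytotoxicity, read by MTT assay, with a stated time of 68 h (a lower number here means a stronger inhibitor, a higher number a weaker inhibitor), compound 1 (`COc1cccc(-c2cccc(NC(=O)C(Cl)Cl)c2)c1`) gives 43300 nM, the only true number among the measured compounds. Compound 2 (`O=C(Nc1cccc(-c2ccc(-c3ccccc3)cc2)c1)C(Cl)Cl`) reads > 50000 nM, which is a limit of the assay and not a number. Compound 3 (`Cc1ccc(-c2cccc(NC(=O)C(Cl)Cl)c2)cc1`) reads > 50000 nM, and this too is only a limit. The clearest feature of the measurements so far is therefore (the limit of > 50000 nM in this assay, at which 2 of the 3 values shown sit), and compound 3 is one of the two compounds resting there.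

Compound 4 (`O=C(Nc1cccc(-c2ccccc2)c1)C(Cl)Cl`) differs from compound 3 by a single change on the outer ring: hydrogen in place of methyl on an aromatic carbon. Going by the values given here, only one measured step bears on this change, as it also alters the group on that aromatic carbon: a step that the two limits leave unreadable from compound 2 to compound 3. That step has no readable size, so it gives neither a magnitude nor a direction for the new change. Among the compounds with values here, the only numerical guide is the close analogue compound 1 at 43300 nM, which keeps the expectation for compound 4 in the same weak range. The estimated change is an at least 1.1-fold lower number from compound 3 to compound 4 (0.04 log units; that floor lies within the scatter), and no shift beyond the scatter is expected. Compound 4 is expected at 45000 nM, with an estimated range of 22000 nM to 80000 nM, and the assay may again report only a limit.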

Compound 4, half-maximal inhibitory concentration: 46800 nM
Compound 4: middle estimate off by 1.0-fold (0.02 log units), on the low side; low and high end bracket the measured number.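

In this assay, this aromatic carbon, para to a large group, now has a true number with hydrogen on it, and the two limits can be set against that number only as floors: the change from methyl reads an at least 1.0-fold lower number from compound 3 to compound 4 (0.02 log units; that floor lies within the scatter) and the change from phenyl reads an at least 1.0-fold lower number from compound 2 to compound 4 (0.02 log units; that floor lies within the scatter). Neither floor shows a shift beyond the scatter, but neither fixes the full size of its step. Against a measured partner, the change from methoxy reads a 1.1-fold higher number from compound 1 to compound 4 (0.03 log units; within the scatter) and so gives no separation between the two compounds, while compound 2 and compound 3 remain limits and not numbers: the limit of > 50000 nM in this assay, at which 2 of the 4 values shown sit.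

From the compounds shown here alone, the step between the two limits cannot be read, so the true sizes of the methyl and phenyl changes, and any order between those two groups, stay open. Also open, going by these compounds, is whether an amine, a carboxylic acid or a hydroxyl group on this aromatic carbon would move the number beyond the scatter from that of compound 4.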